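A few compounds are considered here, and "the series" means these few. Any claim that something is new, unique, unknown or untested is made for them only; others in the source may bear on it.

In an ADME assay on MT4 cells (Homo sapiens) for cytotoxicity, read by MTT assay (a higher number here means that more compound is tolerated, a lower number that less compound is tolerated), compound 2 (`Cc1ccc(NC(=O)CSc2nncnc2-c2cccc3ccccc23)c(Br)c1`) gives 166000 nM as its reading, compound 1 (`O=C(CSc1nncnc1-c1cccc2ccccc12)Nc1ccccc1[N+](=O)[O-]`) gives 142000 nM and compound 3 (`Cc1cnc(NC(=O)CSc2nncnc2-c2ccccc2Cl)c(Br)c1`) gives 144000 nM in the same assay. These three numbers lie within the scatter of one another, so compound 2 holds no separate place among them.

Compound 4 (`COC(=O)c1ccc(NC(=O)CSc2nncnc2-c2cccc3ccccc23)c(Br)c1`) differs from compound 2 at one position: methoxycarbonyl in place of methyl on an aromatic carbon (methoxycarbonyl in place of methyl on an aromatic carbon, meta to a bromo group). For the measured compounds named here, no measured compound carries methoxycarbonyl, and no measured step changes this position.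

Going by the values given here, the nearest evidence is the one measured step on the group at the amide-type nitrogen, a 1.2-fold higher number from compound 1 to compound 2 (0.07 log units; within the scatter) in size. With that step inside the scatter, no step beyond the scatter is expected in this assay for the new change, and neither direction is favoured.

The expected step is small (a 1.1-fold lower number from compound 2 to compound 4 (0.04 log units; within the scatter)). The estimate for compound 4 is 150000 nM with an estimated range from 70000 nM to 280000 nM as its bounds.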

Compound 4, half-maximal cytotoxic concentration: 173000 nM
Beside the measured number, compound 4's estimate is 1.2-fold (0.06 log units) below it, and the stated range covers the measured number.
By their numbers in this assay, from the lowest: compounds 1, 3, 2 and 4 (each within the scatter of the next).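

In this assay, the aromatic carbon meta to a bromo group now has a measured step of its own, with methoxycarbonyl in place of methyl giving a 1.0-fold higher number from compound 2 to compound 4 (0.02 log units; within the scatter). Methyl has 1 heavy atom and methoxycarbonyl has 4, with 2 hydrogen-bond acceptors entering, yet the reading stays within the scatter; until now the only measured step was the swap of groups on the amide-type nitrogen. No measured property bears on this result, so the flat reading remains without an explanation.

From the compounds shown here alone, whether an amine, a carboxylic acid or a longer chain on this carbon would also stay within the scatter remains open. Also open, going by these compounds, is whether methoxycarbonyl in place of methyl reads the same on the core of compound 3.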